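Meta-aryl variation on the shared core: toward compound 4

This account rests on a few compounds, and the source may have more. Where it says the series, first, only, none or still open, it means among the compounds named here.

Measured so far in a functional assay on BJAB cells (Homo sapiens) for antiproliferative activity, with a stated time of 4 days; a higher number here means that more compound is needed for the effect, a lower number that less compound is needed:
- compound 1, `COc1cccc(-c2c(C)nn(-c3nc(-c4ccc(Cl)c(Cl)c4)c(SC(C)C)s3)c2C(=O)O)c1`: 14000 nM
- compound 2, `COc1ccc(C)cc1-c1c(C)nn(-c2nc(-c3ccc(Cl)c(Cl)c3)c(SC(C)C)s2)c1C(=O)O`: 9500 nM
- compound 3, `Cc1nn(-c2nc(-c3ccc(Cl)c(Cl)c3)c(SC(C)C)s2)c(C(=O)O)c1-c1cccc(C(F)(F)F)c1`: 22000 nM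

Compound 2 holds the lowest number of the three, but its margin to compound 1 is small: a 1.5-fold lower number from compound 1 to compound 2 (0.17 log units; within the scatter), within the scatter. Its margin to compound 3 is larger: a 2.3-fold higher number from compound 2 to compound 3 (0.36 log units; beyond the scatter), beyond the scatter though modest. Between compound 1 and compound 3 the step is a 1.6-fold higher number from compound 1 to compound 3 (0.20 log units; within the scatter), again within the scatter.

The unmeasured compound 4, `Cc1nn(-c2nc(-c3ccc(Cl)c(Cl)c3)c(SC(C)C)s2)c(C(=O)O)c1-c1cccc(F)c1`, differs from compound 2 as follows: 3-fluorophenyl in place of 2-methoxy-5-methylphenyl on an aromatic carbon

The two measured steps that bear on this are the moves away from 2-methoxy-5-methylphenyl, from compound 2 to compound 1 (within the scatter) and a 2.3-fold higher number from compound 2 to compound 3 (0.36 log units; beyond the scatter). Both point toward a somewhat higher number when that group is replaced by a phenyl carrying a single group on the ring, with the size depending on the group. A modest rise is therefore expected for compound 4 in this assay, of about a 1.6-fold higher number from compound 2 to compound 4 (0.20 log units; within the scatter).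

Compound 4 is thus estimated at 15000 nM, with a range from 7000 nM to 32000 nM.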

Compound 4, half-maximal effective concentration: 900 nM
Beside the measured number, compound 4's estimate is 17-fold (1.22 log units) above it, and the stated range ends above it.
By their numbers in this assay, from the lowest: compound 4; then compounds 2, 1 and 3 (each within the scatter of the next, the first and the last beyond it).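

In this assay the aryl group on this aromatic carbon of the shared core can move the number much further than the small steps among compound 1, compound 2 and compound 3 indicated, with an 11-fold lower number from compound 2 to compound 4 (1.02 log units; beyond the scatter) on replacing 2-methoxy-5-methylphenyl by 3-fluorophenyl. A change of the single group on the phenyl is enough, with a 16-fold lower number from compound 1 to compound 4 (1.19 log units; beyond the scatter) for fluoro in place of methoxy and a 24-fold lower number from compound 3 to compound 4 (1.39 log units; beyond the scatter) for fluoro in place of trifluoromethyl, so among these compounds fluoro alone stands apart. The data shown give no explanation for the size of these steps.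

A chloro or hydroxy group on that phenyl, or a phenyl with no added group, would show whether the low number is specific to fluoro. From the compounds shown here alone, whether the gain survives an amide in place of the carboxy group remains open.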